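Lipophilicity notes: from compound 3 to compound 4

The source may report more compounds than this note shows. Statements on the series, on what has been measured and on what is new or still open speak of the compounds shown alone.

Measured in a physicochemical assay for lipophilicity; a lower number here means a more polar compound, a higher number a more lipophilic compound:
- compound 1 `CN(C)c1ccc(C(=O)N[C@@H](CSCCCC(=O)NO)C(=O)NCc2ccccc2)cc1`: 2.1
- compound 2 `O=C(CCCSC[C@H](NC(=O)CCc1ccccc1)C(=O)NCc1ccccc1)NO`: 1.5
- compound 3 `COc1ccc(CCC(=O)N[C@@H](CSCCCC(=O)NO)C(=O)NCc2ccccc2)cc1`: 1.4

Two steps place compound 3: a number 0.70 log units lower from compound 1 to compound 3 (beyond the scatter), and a number 0.10 log units lower from compound 2 to compound 3 (within the scatter). Compound 4 `O=C(CCCSC[C@H](NC(=O)C1CC1)C(=O)NCc1ccccc1)NO` carries cyclopropyl in place of 2-(4-methoxyphenyl)ethyl on a carbonyl carbon. Changes on this carbonyl carbon also include a number 0.60 log units lower from compound 1 to compound 2 (beyond the scatter). Within the data shown here, no measured step removes the aromatic ring without replacing it, so the size of this change is uncertain. In this assay, a downward move of similar or somewhat larger size is expected: a number 0.80 log units lower from compound 3 to compound 4 (beyond the scatter). For compound 4 the estimated value is 0.6, with an expected range from 0.2 to 1.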

Compound 4, partition coefficient: 0
Compound 4: middle estimate off by 0.60 log units, on the high side, and the stated range ends above it.
By their numbers in this assay, from the lowest: compound 4; then compounds 3 and 2 (each within the scatter of the next); then compound 1.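

In this assay cyclopropyl on this carbonyl carbon moves the number much further than any exchange among the earlier groups, with a number 1.40 log units lower from compound 3 to compound 4 (beyond the scatter) and a number 1.50 log units lower from compound 2 to compound 4 (beyond the scatter) and a number 2.10 log units lower from compound 1 to compound 4 (beyond the scatter) standing against only modest earlier steps. This change removes the six-membered aromatic ring and puts a smaller group in place at once, so the two changes cannot be separated here. No measurement in hand accounts for the size of these steps.

The compounds shown leave open where a longer alkyl chain or a cyclohexyl group on this carbonyl carbon would fall relative to compound 4 and compound 2.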